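This account rests on a few compounds, and the source may have more. Where it says the series, first, only, none or still open, it means among the compounds named here.

In a functional assay on BeWo cells (Homo sapiens) for inhibition, read by MTT assay, with a stated time of 72 h (on this read-out lower numbers stand for stronger inhibition and higher numbers for weaker inhibition), compound 3 `CCCC(=O)N1CCN(c2nnc3nncn3n2)CC1` gives 6730 nM, the second highest of three numbers. Compound 1 `CCCCC(=O)N1CCN(c2nnc3nncn3n2)CC1` gives 1720 nM, and the step of a 3.9-fold higher number from compound 1 to compound 3 (0.59 log units; beyond the scatter) separates them. Compound 2 `CC(=O)N1CCN(c2nnc3nncn3n2)CC1` gives 13100 nM, and the step of a 1.9-fold lower number from compound 2 to compound 3 (0.29 log units; within the scatter) sits between the two. Compound 4 `CC(C)COC(=O)N1CCN(c2nnc3nncn3n2)CC1` differs from compound 3 at the carbonyl carbon whose other neighbour is the amide-type nitrogen in a ring: isobutoxy in place of propyl on a carbonyl carbon, so that propylcarbonyl becomes isobutoxycarbonyl.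

The measured steps that bear on this change all concern what is attached to that carbonyl carbon. The step of a 7.6-fold higher number from compound 1 to compound 2 (0.88 log units; beyond the scatter) and the step of a 3.9-fold higher number from compound 1 to compound 3 (0.59 log units; beyond the scatter) show that removing carbons from the chain raises the number, and the step of a 1.9-fold lower number from compound 2 to compound 3 (0.29 log units; within the scatter) points, as far as its size allows, the same way. Within the data shown here, the isobutoxy group that enters brings five heavy atoms against the three that leave, so the pattern seen with compound 1 suggests a lower number for compound 4, though the oxygen now present has no counterpart among compounds 1 to 3. Compound 4 is therefore expected to show the step of a 2.7-fold lower number from compound 3 to compound 4 (0.43 log units; beyond the scatter), and its value in this assay is estimated at 2500 nM, within the range 900 nM to 7000 nM.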

Compound 4, half-maximal inhibitory concentration: 13100 nM
Beside the measured number, compound 4's estimate is 5.2-fold (0.72 log units) below it; the whole stated range lies below it.
By their numbers in this assay, from the lowest: compound 1; then compounds 3, 2 and 4 (each within the scatter of the next).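

In this assay the isobutoxy group on the carbonyl carbon does not carry on the pattern of the plain chains: the step is a 1.9-fold higher number from compound 3 to compound 4 (0.29 log units; within the scatter) even though isobutoxy has more heavy atoms than propyl, and no change at the digits printed from compound 2 to compound 4 (within the scatter) leaves it level with the methyl member of the set. Butyl stays apart, with a 7.6-fold higher number from compound 1 to compound 4 (0.88 log units; beyond the scatter) as the only new step beyond the scatter, so a larger group at this position does not by itself give the lower number seen with compound 1. Nothing available here explains this result.

On these data alone, whether the oxygen or the branching of isobutoxy goes with the higher number stays open. An isobutyl group or a straight butoxy group on the same carbonyl carbon would separate the two, and a pentyl chain would show whether the trend of the plain chains continues past butyl.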